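The compounds below may be only part of what the source reports. "The series", "measured", "known", "first", "only" and "open" are said of these compounds alone.

Measured in a functional assay on HeLa cells (Homo sapiens) for antiproliferative activity, read by MTT assay, with a stated time of 72 h (on this read-out higher numbers stand for weaker inhibition and lower numbers for stronger inhibition), so far:

Compound 1, `O=C1O/C(=C\Cn2cc(-c3cc(F)cc(F)c3)nn2)C(OCc2ccccc2)=C1OCc1ccccc1`, gives 17700 nM.
Compound 2, `CC(C)(C)OC(=O)N1CCN(C(=S)SCc2cn(C[C@H](O)[C@H]3OC(=O)C(OCc4ccccc4)=C3OCc3ccccc3)nn2)CC1`, gives > 100000 nM.
Compound 3, `COc1ccccc1-c1cn(C[C@H](O)[C@H]2OC(=O)C(OCc3ccccc3)=C2OCc2ccccc2)nn1`, gives > 100000 nM.

The value for compound 2 is a limit of the assay and not a number. The value for compound 3 is likewise a limit and not a number. Compound 3 therefore stands at the limit of > 100000 nM in this assay, at which 2 of the 3 values shown sit, so no order between compound 2 and compound 3 can be read, and only compound 1 gives a number, and compound 1 differs from compound 3 in more than one place, so its value stands on its own.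

Compound 4 is `Cc1ccc(S(=O)(=O)NCc2cn(C[C@H](O)[C@H]3OC(=O)C(OCc4ccccc4)=C3OCc3ccccc3)nn2)cc1`. The change from compound 3 is (((4-methylphenyl)sulfonyl)amino)methyl in place of 2-methoxyphenyl on an aromatic carbon.

Within the data shown here, no measured pair shows this kind of change, and since compound 3 sits at the limit, any gain for compound 4 would have to be large before a number appeared. Among the measured compounds shown here, nothing among the measured compounds points to such a gain, so the step from compound 3 to compound 4 in this assay is expected to be none beyond the scatter, with compound 4 most likely reported as a limit again. The expected step is a number no higher from compound 3 to compound 4 (the limit leaves the size open). For compound 4 the estimate in this assay is 100000 nM, within 30000 nM to 300000 nM.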

Compound 4, half-maximal inhibitory concentration: 14400 nM
The estimate for compound 4 lay 6.9-fold (0.84 log units) above the measured number; the whole stated range lies above it.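

Exchanging 2-methoxyphenyl for (((4-methylphenyl)sulfonyl)amino)methyl on the aromatic carbon of the five-membered aromatic ring with 3 nitrogen gives, in this assay, an at least 6.9-fold lower number from compound 3 to compound 4 (0.84 log units; beyond the scatter), so the read-out at this position does respond to the group it bears. Compound 3 carries a limit and not a number, so the step fixes only a minimum size, and that limit is not unique to compound 3: the limit of > 100000 nM in this assay, at which 2 of the 4 values shown sit. Both the leaving and the entering group hold one six-membered aromatic ring of carbon only, so the presence of such a ring at this position does not alone set the read-out for this pair.

Which part of the entering group goes with the step stays open, as the sulfonyl group, the amino hydrogen, the methylene link and the 4-methylphenyl ring all arrive together. A plain aminomethyl group, a carboxamide in place of the sulfonamide, or a phenylsulfonyl group lacking the methyl would help to separate these parts.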